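A few compounds are considered here, and "the series" means these few. Any claim that something is new, unique, unknown or untested is made for them only; others in the source may bear on it.

Among the compounds with values here, in a functional assay (ileum) with Cavia porcellus as the target (a lower number here means a stronger inhibitor, a higher number a weaker inhibitor), compound 2 `CCCc1c(OCCCCCCO)ccc(C(C)=O)c1O` gives 3980 nM, the highest of the three numbers so far. Compound 1 `CCCc1c(OCCCCCCCC(=O)O)ccc(C(C)=O)c1O` gives 794 nM and compound 3 `CCCc1c(OCCCCCCCCCC(=O)O)ccc(C(C)=O)c1O` gives 794 nM, so these two stand level. The next compound is compound 4 `CCCc1c(OCCCCCCCCCCc2nn[nH]n2)ccc(C(C)=O)c1O`, which differs from compound 2 as follows: 4-(2H-tetrazol-5-yl)butyl in place of hydroxy on a saturated chain carbon, six bonds along the chain from an oxygen on an aromatic ring. In words, this is 4-(2H-tetrazol-5-yl)butyl in place of hydroxy on a saturated chain carbon, six bonds along the chain from an oxygen on an aromatic ring.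

The nearest measured change is a 5.0-fold lower number from compound 2 to compound 3 (0.70 log units; beyond the scatter), with 3-carboxypropyl entering at the same place. The step of a 5.0-fold higher number from compound 1 to compound 2 (0.70 log units; beyond the scatter) is of the same modest size, while no change at the digits printed from compound 1 to compound 3 (within the scatter) shows no separation between the two carboxy compounds. Within the data shown here, no measured compound carries the tetrazole ring, so the transfer is uncertain. A modest step to a lower number is expected, in line with the value of compound 3 at 794 nM. The expected step is a 5.0-fold lower number from compound 2 to compound 4 (0.70 log units; beyond the scatter). Compound 4 is estimated at 800 nM, with an expected range of 250 nM to 2500 nM.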

Compound 4, half-maximal inhibitory concentration: 3160 nM
The estimate for compound 4 lay 4.0-fold (0.60 log units) below the measured number; the measured number lies above the stated range.
By their numbers in this assay, from the lowest: compounds 1 and 3 (each within the scatter of the next); then compounds 4 and 2 (each within the scatter of the next).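

In this assay, the 4-(2H-tetrazol-5-yl)butyl group on this saturated chain carbon does not match the result of the 3-carboxypropyl group: the printed step is a 1.3-fold lower number from compound 2 to compound 4 (0.10 log units; within the scatter), so compound 4 stands level with the hydroxy compound. Against the two carboxy compounds, the steps are a 4.0-fold higher number from compound 3 to compound 4 (0.60 log units; beyond the scatter) and a 4.0-fold higher number from compound 1 to compound 4 (0.60 log units; beyond the scatter), which shows that in this series the tetrazole ring does not stand in for the terminal carboxy group at this chain end. The evidence at hand offers no explanation for this separation.

Compound 4 is the only tetrazole shown, so the effect of a shorter or longer chain carrying this ring remains open. Also open, going by these compounds, is whether a primary amine or a primary amide at the chain end would stand with the carboxy compounds or with compound 2.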